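The source may hold more compounds than are shown below. What is called first, only, known or untested is meant among the compounds shown, and "the series" means these compounds.

Measured so far:
compound 1, `Cc1cccc2sc(NC(=O)COc3ccc4cc(/C=C5/SC(=O)NC5=O)ccc4c3)nc12` — in an assay on isolated protein for inhibition of histone deacetylase 4 (Homo sapiens), with a stated time of 1 h (on this read-out lower numbers stand for stronger inhibition and higher numbers for weaker inhibition), compound 1 gives 1200 nM
compound 2, `Cc1ccc(NC(=O)COc2ccc3cc(/C=C4/SC(=O)NC4=O)ccc3c2)cc1Cl` — in this assay compound 2 gives 1100 nM

Going by the values given here, compound 2 stands at the lower of the two numbers so far, but its nearest neighbour, compound 1, lies within the scatter of it: the step of a 1.1-fold lower number from compound 1 to compound 2 (0.04 log units; within the scatter) does not separate the two compounds, so neither can be called the stronger inhibitor on these numbers.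

Compound 3, `O=C(COc1ccc2cc(/C=C3/SC(=O)NC3=O)ccc2c1)Nc1cccc(Cl)c1`, is the next member to be measured. Its difference from compound 2 is hydrogen in place of methyl on an aromatic carbon.

Of the measured steps, only a 1.1-fold lower number from compound 1 to compound 2 (0.04 log units; within the scatter) exists, and it concerns a different change, the exchange of the whole group on the amide-type nitrogen; it was within the scatter. Among the compounds with values here, no measured step removes a methyl from an aromatic carbon of the aryl group on the amide nitrogen. On this basis no step beyond the scatter is expected for the change to compound 3, in either direction; the expected step is a 1.2-fold higher number from compound 2 to compound 3 (0.07 log units; within the scatter).

For compound 3 in this assay the estimate is 1300 nM, with a range from 600 nM to 2800 nM.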

Compound 3, half-maximal inhibitory concentration: 3800 nM
For compound 3 the middle estimate is 2.9-fold (0.47 log units) below the measured one, outside the stated range (above it).
By their numbers in this assay, from the lowest: compounds 2 and 1 (each within the scatter of the next); then compound 3.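

In this assay, going by these compounds alone, the methyl of the 3-chloro-4-methylphenyl group proves to count: replacing it with hydrogen gives a 3.5-fold higher number from compound 2 to compound 3 (0.54 log units; beyond the scatter) and is the first single-place change to pass the scatter. The exchange of the whole group on the amide-type nitrogen, unreadable between the two methyl-bearing groups, becomes readable when the incoming group is 3-chlorophenyl, with a 3.2-fold higher number from compound 1 to compound 3 (0.50 log units; beyond the scatter) as the result. Among these three compounds, the two carrying a methyl therefore sit together and the one without it sits apart, and nothing at hand accounts for this.

Still open, from the compounds shown here alone, is whether the methyl keeps its worth in a 4-methylphenyl group without the chloro group, and whether the chloro group itself contributes anything at all. Equally open, going by these compounds, is whether ethyl, methoxy or an amine in the place of the methyl would track with compound 2 or with compound 3, which would show whether this position accepts groups other than methyl.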